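From 1-benzofuran-2-yl to ethynyl on the shared core

The source may hold more compounds than are shown below. What is called first, only, known or untested is meant among the compounds shown, and "the series" means these compounds.

In a functional assay on HL-60 cells (Homo sapiens) for antiproliferative activity, read by XTT assay, with a stated time of 72 h (on this read-out higher numbers stand for weaker inhibition and lower numbers for stronger inhibition), three compounds with one shared core have been tested so far. Compound 1 (`CNc1ncnc2c1c(-c1cccs1)cn2[C@@H]1O[C@H](CO)[C@@H](O)[C@H]1O`), with thiophen-2-yl, gives > 20000 nM as a limit and not a number. Compound 2 (`CNc1ncnc2c1c(-c1ccccc1)cn2[C@@H]1O[C@H](CO)[C@@H](O)[C@H]1O`), with phenyl, gives > 20000 nM as a limit too. Going by the values given here, compound 3 (`CNc1ncnc2c1c(-c1cc3ccccc3o1)cn2[C@@H]1O[C@H](CO)[C@@H](O)[C@H]1O`), with 1-benzofuran-2-yl, gives 8950 nM as the only actual number of the three.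

Compound 4 (`C#Cc1cn([C@@H]2O[C@H](CO)[C@@H](O)[C@H]2O)c2ncnc(NC)c12`) carries ethynyl in place of 1-benzofuran-2-yl on an aromatic carbon, and the change counts as ethynyl in place of 1-benzofuran-2-yl on an aromatic carbon on the five-membered aromatic ring of the core.

Among the compounds with values here, two measured steps bear on this: an at least 2.2-fold lower number from compound 1 to compound 3 (0.34 log units; beyond the scatter) and an at least 2.2-fold lower number from compound 2 to compound 3 (0.34 log units; beyond the scatter) are both modest by what can be read. Read backwards, they hint at a higher number once 1-benzofuran-2-yl leaves. Yet both compare only ring-bearing groups, and ethynyl has no ring, so they carry over weakly. No step beyond the scatter is therefore expected, though with wide uncertainty, and a limit remains possible.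

The expected outcome is a 1.3-fold lower number from compound 3 to compound 4 (0.11 log units; within the scatter) in this assay as a rough estimate. The estimate for compound 4 is 7000 nM with an expected range from 700 nM to 20000 nM in all.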

Compound 4, half-maximal inhibitory concentration: 9060 nM
Compound 4: the middle estimate sits 1.3-fold (0.11 log units) below what was measured, within the range that was stated.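

In this assay, replacing 1-benzofuran-2-yl with ethynyl gives a 1.0-fold higher number from compound 3 to compound 4 (0.01 log units; within the scatter), so at this position a group with no ring and 2 heavy atoms matches one with two aromatic rings and 9 heavy atoms. Until now, only 1-benzofuran-2-yl had given a number, which left open that a number here required that group, but ethynyl also separates from the phenyl and thiophen-2-yl groups, with an at least 2.2-fold lower number from compound 2 to compound 4 (0.34 log units; beyond the scatter) and an at least 2.2-fold lower number from compound 1 to compound 4 (0.34 log units; beyond the scatter), so among these four compounds the read-out does not follow the size of the group. Both of these last steps start from a limit and not a number, so their full size cannot be read, and compound 1 and compound 2 share that limit: the limit of > 20000 nM in this assay, at which 2 of the 4 values shown sit.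

The compounds shown leave open whether ethynyl is special here or whether other small groups, such as methyl, nitrile or bromine, or a longer chain such as prop-1-yn-1-yl, would give a similar number. They also leave open whether any group at this position can give a clearly lower number than compound 3 and compound 4 share.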